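The source may hold more compounds than are shown below. What is called first, only, known or untested is meant among the compounds shown, and "the series" means these compounds.

Measured so far:
- compound 1 `Cn1cc(-c2ccccc2Oc2ccccc2)ccc1=O`: 4800 nM
- compound 2 `CCS(=O)(=O)Nc1ccc(Oc2ccccc2)c(-c2cn(C)c(=O)c3[nH]ccc23)c1`: 14 nM

In a functional assay on MX1 cells (Homo sapiens) for antiproliferative activity, with a stated time of 72 h (a higher number here means that more compound is needed for the effect, a lower number that less compound is needed), compound 2 gives 14 nM, the lowest of the two numbers shown, while compound 1 gives 4800 nM; the two differ beyond the scatter, but they differ in more than one place, so no single step can be read from them.

Compound 3 `Cn1cc(-c2cc(S(N)(=O)=O)ccc2Oc2ccccc2)c2cc[nH]c2c1=O` is not yet measured. It differs from compound 2 by sulfamoyl in place of (ethylsulfonyl)amino on an aromatic carbon. For the measured compounds named here, no step between measured compounds covers this change. The shared core of compound 2 is kept, so a moderate loss is expected, a 3.6-fold higher number from compound 2 to compound 3 (0.55 log units; beyond the scatter). For compound 3 the estimate is 50 nM, with a range from 10 nM to 300 nM.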

Compound 3, half-maximal effective concentration: 56 nM
The estimate for compound 3 lay 1.1-fold (0.05 log units) below the measured number, within the range that was stated.
By their numbers in this assay, from the lowest: compound 2; then compound 3; then compound 1.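

In this assay, for the compounds shown here, sulfamoyl in place of (ethylsulfonyl)amino on this aromatic carbon, para to a phenoxy group, gives a 4.0-fold higher number from compound 2 to compound 3 (0.60 log units; beyond the scatter), the first single-place step. The position accepts the swap with only a modest loss, even though the two groups have equal hydrogen-bond donor and acceptor counts, so those counts alone do not account for the difference. Nothing available explains the step.

From the compounds shown here alone, how an amine, a carboxylic acid or a longer sulfonyl chain would behave at this position remains open.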